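A Methoxyphenyl Takes the Place of a Methylphenyl

A few compounds are considered here, and "the series" means these few. Any claim that something is new, unique, unknown or untested is made for them only; others in the source may bear on it.

Compound 1, `CCCc1nc(-c2ccccc2)c(CNCCN2CCN(c3cccc(C)c3)CC2)o1`, was tested in an assay on HEK293 cells for inhibition of Voltage-dependent T-type calcium channel subunit alpha-1G (Homo sapiens), read by fluorescence, tested at 10 uM (on this read-out lower numbers stand for less inhibition and higher numbers for more inhibition at the one concentration tested (going by the name of the read-out)), where compound 1 gives 43.1%. That is the lowest of the three numbers seen so far. Compound 2, `CCCc1nc(-c2ccccc2)c(CNCCCN2CCN(c3ccc(F)cc3)CC2)o1`, gives 62.5%, a number that sits beyond the scatter above that of compound 1. Compound 3, `CCCc1nc(-c2ccccc2)c(CNCCN2CCN(C(c3ccccc3)c3ccccc3)CC2)o1`, gives 71.9%, also beyond the scatter above compound 1 and the highest of the three. Going by the values given here, compounds 2 and 3 each differ from compound 1 in more than one place, so no single step between any two of these measured compounds can be read off.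

Compound 4, `CCCc1nc(-c2ccccc2)c(CNCCN2CCN(c3ccc(OC)cc3)CC2)o1`, has not yet been measured. Its change from compound 1 is 4-methoxyphenyl in place of 3-methylphenyl on an amine nitrogen in a ring. Among the compounds with values here, with no measured step of this kind to lean on, the step expected in this assay is a number 6.9 percentage points higher from compound 1 to compound 4 (within the scatter), a small rise that would stay within the usual scatter. Compound 4 is therefore estimated at 50%, with a range from 30% to 70%.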

Compound 4, a percentage reported as inhibition, at one concentration (the size of the read-out at that concentration, not a potency): 51.5%
Beside the measured number, compound 4's estimate is 1.5 percentage points below it; the range from low to high includes it.
By their numbers in this assay, from the lowest: compounds 1 and 4 (each within the scatter of the next); then compounds 2 and 3 (each within the scatter of the next).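

In this assay, going by these compounds alone, the swap gives a number 8.4 percentage points higher from compound 1 to compound 4 (within the scatter), the first comparison here in which only one place in the molecule differs. At this position on an amine nitrogen in a ring, 4-methoxyphenyl can therefore stand in for 3-methylphenyl without a shift that can be told from the usual scatter, even though it brings in an oxygen and a hydrogen-bond acceptor. No measurement offers an explanation for this result.

The swap alters both the group and where it sits on the phenyl ring, so 3-methoxyphenyl and 4-methylphenyl would be needed to tell those two changes apart. Also open, going by these compounds, is how this position would respond to a phenyl ring carrying an amine or a carboxylic acid.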